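Swapping a Phenol Ring for Dichlorophenyl: Lipophilicity Outlook

The compounds below may be only part of what the source reports. "The series", "measured", "known", "first", "only" and "open" are said of these compounds alone.

Compounds measured so far:
- compound 1, `CN(C)c1ccc(C2SCC(=O)N2NC(=O)CN2C(=O)c3ccccc3C2=O)cc1`: 2.84
- compound 2, `COc1cc(C2SCC(=O)N2NC(=O)CN2C(=O)c3ccccc3C2=O)ccc1O`: 1.31
- compound 3, `O=C(CN1C(=O)c2ccccc2C1=O)NN1C(=O)CSC1c1cccnc1`: 1.25

These three share one core and differ only in the aromatic group attached to a saturated ring carbon. In a physicochemical assay for lipophilicity, in phosphate buffer, measured as octanol-water partition, with a stated time of 24 h (on this read-out lower numbers stand for lower lipophilicity and higher numbers for higher lipophilicity), compound 1 gives the highest number. Compound 2 stands second highest, but its gap to compound 3, a number 0.06 log units lower from compound 2 to compound 3 (within the scatter), lies within the scatter, so the two cannot be ordered. The step of a number 1.53 log units lower from compound 1 to compound 2 (beyond the scatter) is large, as is a number 1.59 log units lower from compound 1 to compound 3 (beyond the scatter).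

Compound 4, `O=C(CN1C(=O)c2ccccc2C1=O)NN1C(=O)CSC1c1ccc(Cl)cc1Cl`, is not yet measured. It differs from compound 2 in one place: 2,4-dichlorophenyl in place of 4-hydroxy-3-methoxyphenyl on a saturated ring carbon. The 4-hydroxy-3-methoxyphenyl group that leaves carries the hydrogen-bond donor and two acceptors counted above; the 2,4-dichlorophenyl group that enters carries none. For the measured compounds named here, the only measured step that bears directly on this kind of change is a number 1.53 log units lower from compound 1 to compound 2 (beyond the scatter), where giving up a 4-(dimethylamino)phenyl for the same hydroxy-methoxy ring lowered the number by a large amount. Reversing that direction, with two chlorines in place of the donor and acceptors, a large upward step in this assay is expected. The expected step is a number 1.79 log units higher from compound 2 to compound 4 (beyond the scatter), and compound 4 is estimated at 3.1, within a range from 2.4 to 3.8.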

Compound 4, partition coefficient: 2.54
Compound 4: the middle estimate sits 0.56 log units above what was measured; measured number inside the range.
By their numbers in this assay, from the lowest: compounds 3 and 2 (each within the scatter of the next); then compounds 4 and 1 (each within the scatter of the next).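

In this assay, replacing the 4-hydroxy-3-methoxyphenyl group with 2,4-dichlorophenyl on the saturated ring carbon gives a large rise, a number 1.23 log units higher from compound 2 to compound 4 (beyond the scatter), and replacing pyridin-3-yl with the same group gives a similar one, a number 1.29 log units higher from compound 3 to compound 4 (beyond the scatter). The comparison with the highest earlier compound, a number 0.30 log units lower from compound 1 to compound 4 (within the scatter), lies within the scatter, so those two compounds cannot be ordered. A high number at this position therefore no longer rests on the 4-(dimethylamino)phenyl group alone, since an aromatic ring with two chlorines and no hydrogen-bond donors or acceptors reaches the same level.

Nothing measured alongside these numbers explains what lies behind the steps. Each swap also replaces a whole aromatic group, so the compounds shown leave open how much of the rise belongs to the chlorines and how much to the loss of the hydroxyl and methoxy groups, and a plain phenyl ring, a phenyl ring with a single chlorine, or a phenyl ring carrying a carboxylic acid would be needed to begin separating those contributions.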